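The source may hold more compounds than are shown below. What is called first, only, known or untested is meant among the compounds shown, and "the series" means these compounds.

Measured so far in a functional assay on HepG2 cells (Homo sapiens) for antiproliferative activity, read by MTT assay, with a stated time of 48 h; on this read-out higher numbers stand for weaker inhibition and lower numbers for stronger inhibition:
- compound 1, `O=C(Nc1cccc(CNc2nccnc2Cl)c1)Nc1ccccc1F`: 10500 nM
- compound 2, `O=C(Nc1cccc(CNc2nccnc2Cl)c1)NC1CCCC1`: 18400 nM
- compound 3, `Cc1ccccc1NC(=O)Nc1cccc(CNc2nccnc2Cl)c1`: 15300 nM

All three compounds share the same core and differ only in the group carried on one amide-type nitrogen. Compound 1 has the lowest number of the three, but the gaps to compound 3 and to compound 2 are both within the scatter, so the three compounds cannot be ranked against one another on these numbers.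

Compound 4, `Cc1cccc(NC(=O)Nc2cccc(CNc3nccnc3Cl)c2)c1`, has not yet been measured. It differs from compound 1 in one place: 3-methylphenyl in place of 2-fluorophenyl on an amide-type nitrogen. Among the measured compounds shown here, the steps that bear on this change are modest. Exchanging the same fluoro for a methyl on the aromatic carbon, a 1.5-fold higher number from compound 1 to compound 3 (0.16 log units; within the scatter), moved the number only slightly; replacing the cyclopentyl by a 2-methylphenyl, a 1.2-fold lower number from compound 2 to compound 3 (0.08 log units; within the scatter), barely moved it at all. For the measured compounds named here, nothing among the measured compounds points to a methyl placed on a different aromatic carbon behaving differently from these cases. The expectation for this assay is therefore a step within the scatter, with no clear direction.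

On that basis compound 4 is estimated to give 13000 nM in this assay, within a range from 6000 nM to 28000 nM, which amounts to an expected step of a 1.2-fold higher number from compound 1 to compound 4 (0.09 log units; within the scatter).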

Compound 4, half-maximal inhibitory concentration: 11200 nM
For compound 4 the middle estimate is 1.2-fold (0.06 log units) above the measured one, and the stated range covers the measured number.
By their numbers in this assay, from the lowest: compounds 1, 4, 3 and 2 (each within the scatter of the next).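

In this assay the 3-methylphenyl group gives three steps, all within the scatter: (a 1.1-fold higher number from compound 1 to compound 4 (0.03 log units; within the scatter)) with 2-fluorophenyl as the group replaced, (a 1.4-fold lower number from compound 3 to compound 4 (0.14 log units; within the scatter)) with 2-methylphenyl replaced, and (a 1.6-fold lower number from compound 2 to compound 4 (0.22 log units; within the scatter)) with cyclopentyl replaced. This amide-type nitrogen has now carried four different groups, and no two of them can be told apart on these numbers, so the two methylphenyl groups, which differ only in where the methyl sits, also read alike within the scatter, as do the aromatic groups and the cyclopentyl ring. Nothing measured here accounts for this flat picture.

The compounds shown leave open whether any group on this nitrogen can move the number beyond the scatter, for example a carboxylic acid, an amine or a longer alkyl chain attached through a phenyl ring. They also leave open what happens when the shared core itself is altered, such as replacing its chlorine with a methoxy group, as all four compounds carry that core unchanged.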